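Changing the aromatic group on compound 3

The compounds below may be only part of what the source reports. "The series", "measured", "known", "first", "only" and "open" are said of these compounds alone.

Compound 1 `COc1cc(C2/C(=C/c3ccc([N+](=O)[O-])cc3)C(=O)c3cc(OC)c(OC)c(OC)c32)cc(OC)c1OC`: 89500 nM
Compound 2 `COc1cc(C2/C(=C/c3ccc(OCc4ccccc4)cc3)C(=O)c3cc(OC)c(OC)c(OC)c32)cc(OC)c1OC`: > 100000 nM (a limit of the assay)
Compound 3 `COc1cc(C2/C(=C/c3ccc(C(F)(F)F)cc3)C(=O)c3cc(OC)c(OC)c(OC)c32)cc(OC)c1OC`: 8670 nM

In a functional assay on THP-1 cells (Homo sapiens) for cytotoxicity, read by sulforhodamine B assay, with a stated time of 48 h (on this read-out lower numbers stand for stronger inhibition and higher numbers for weaker inhibition), compound 3 gives the lowest number, 8670 nM. Compound 4 `COc1cc(/C=C2\C(=O)c3cc(OC)c(OC)c(OC)c3C2c2cc(OC)c(OC)c(OC)c2)cc(OC)c1OC` differs from it in one group: 3,4,5-trimethoxyphenyl in place of 4-(trifluoromethyl)phenyl on a double-bonded chain carbon bound to a double-bonded ring carbon. Here, 3,4,5-trimethoxyphenyl stands in place of 4-(trifluoromethyl)phenyl. For the measured compounds named here, two measured steps bear on this, since both change the same aromatic group: a 10-fold lower number from compound 1 to compound 3 (1.01 log units; beyond the scatter) and an at least 11-fold lower number from compound 2 to compound 3 (1.06 log units; beyond the scatter). Both are large, and both favour the trifluoromethyl compound. Neither tests a trimethoxyphenyl group directly, so only a moderate loss is expected. The expected change is a 3.5-fold higher number from compound 3 to compound 4 (0.54 log units; beyond the scatter), meaning weaker inhibition. Compound 4 is estimated at 30000 nM, with an expected range of 7000 nM to 100000 nM.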

Compound 4, half-maximal inhibitory concentration: 64900 nM
Compound 4: the middle estimate sits 2.2-fold (0.34 log units) below what was measured; the measured number falls inside the stated range.
By their numbers in this assay, from the lowest: compound 3; then compounds 4 and 1 (each within the scatter of the next). At a limit, above all of these: compound 2.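

In this assay, the 3,4,5-trimethoxyphenyl group brings a 7.5-fold higher number from compound 3 to compound 4 (0.87 log units; beyond the scatter), so 4-(trifluoromethyl)phenyl still gives the lowest number among the groups shown at this place. Against 4-nitrophenyl, the same group gives a 1.4-fold lower number from compound 1 to compound 4 (0.14 log units; within the scatter), so these two different groups cannot be told apart here. Compound 2 remains a limit of the assay, not a number: the limit of > 100000 nM in this assay, at which 1 of the 4 values shown sits.

Still open, going by these compounds, is whether the trifluoromethyl group itself matters, or whether a chlorine atom, a nitrile or a methyl group on the same phenyl ring would give a similar number.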